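This account rests on a few compounds, and the source may have more. Where it says the series, first, only, none or still open, it means among the compounds named here.

In an ADME assay (liver) for metabolic stability, with Liver microsome (Rattus norvegicus) as the target, read by LC-MS, using microsomes, with a stated time of 15 min, tested at 5 uM (a lower number here means that less of the compound is left, a higher number that more of the compound is left), compound 1 `CC(=O)Nc1nc(C)c(-c2nc(CC(F)(F)F)no2)s1` gives 72.9% and compound 2 `CC(=O)Nc1nc(C)c(-c2nc(CC(C)(C)CO)no2)s1` gives 94%, the higher of the two numbers. Among the compounds with values here, the only measured step, a number 21.1 percentage points higher from compound 1 to compound 2 (beyond the scatter), swaps trifluoromethyl for 1-(hydroxymethyl)-1-methylethyl on a saturated chain carbon bound to an aromatic carbon. Compound 3 `CC(=O)Nc1nc(C)c(-c2nc(CC(C)(C)C(C)O)no2)s1` keeps the shared core and alters only the end of the chain of compound 2: methyl in place of hydrogen on a saturated chain carbon bound to an oxygen on a saturated carbon and a saturated chain carbon. Hydroxymethyl thus becomes 1-hydroxyethyl. Within the data shown here, no measured step covers this exchange, and the one available step, involving a much larger change of group, offers only a loose guide to its size. With compound 2 at 94%, little room remains upward in this assay, so the direction, if any, is expected to be slightly downward, with no step beyond the scatter. The expected change is a number 6 percentage points lower from compound 2 to compound 3 (within the scatter). The estimate for compound 3 is 88%, with an expected range from 74% to 99%.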

Compound 3, percent of the compound remaining: 91.5%
For compound 3 the middle estimate is 3.5 percentage points below the measured one; measured number inside the range.
By their numbers in this assay, from the lowest: compound 1; then compounds 3 and 2 (each within the scatter of the next).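

In this assay, methyl in place of hydrogen on a saturated chain carbon bound to an oxygen on a saturated carbon and a saturated chain carbon turns hydroxymethyl into 1-hydroxyethyl and gives a number 2.5 percentage points lower from compound 2 to compound 3 (within the scatter), so this place accepts the added methyl with no difference that can be told from the scatter. The replacement of trifluoromethyl on a saturated chain carbon bound to an aromatic carbon by 2-hydroxy-1,1-dimethylpropyl gives a number 18.6 percentage points higher from compound 1 to compound 3 (beyond the scatter) and thus shows that the earlier difference seen with 1-(hydroxymethyl)-1-methylethyl is not confined to that single group. Nothing at hand bears on the reason behind these numbers.

The compounds shown leave open how a chain ending in a methyl ether, an amine or a carboxylic acid would read in this assay, and so whether the hydroxyl group has any part in these numbers. They also leave open whether a longer chain or a second methyl on the carbon that carries the hydroxyl group would still stay within the scatter of compound 2.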